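Thiourea series: aryl-to-propyl swap on the thiourea nitrogen

This account rests on a few compounds, and the source may have more. Where it says the series, first, only, none or still open, it means among the compounds named here.

Measured so far:
- compound 1 `COc1cc2c(cc1OC)C(=O)C(CC1CCN(C(=S)Nc3ccccc3)CC1)C2` — 300 mg/kg
- compound 2 `COc1cc2c(cc1OC)C(=O)C(CC1CCN(C(=S)Nc3ccc(C)cc3)CC1)C2` — 100 mg/kg
- compound 3 `COc1cc2c(cc1OC)C(=O)C(CC1CCN(C(=S)Nc3ccc(Cl)cc3)CC1)C2` — 100 mg/kg

The three compounds share one core and differ only on the thiourea nitrogen. In a functional assay on the whole organism (strain Swiss albino) with Mus musculus as the target, in the maximal electroshock model, with a stated time of 4 h (on this read-out higher numbers stand for an effect only at larger amounts of compound and lower numbers for an effect already at smaller amounts), compound 3 gives 100 mg/kg, level with compound 2 at the digits shown, the two together being the lowest numbers of the three; compound 1 stands furthest away, a 3.0-fold lower number from compound 1 to compound 3 (0.48 log units; beyond the scatter). The other steps: a 3.0-fold lower number from compound 1 to compound 2 (0.48 log units; beyond the scatter) and no change at the digits printed from compound 2 to compound 3 (within the scatter).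

Compound 4 `CCCNC(=S)N1CCC(CC2Cc3cc(OC)c(OC)cc3C2=O)CC1` is not yet measured. The change from compound 3 is propyl in place of 4-chlorophenyl on an amide-type nitrogen.

Going by the values given here, none of the measured steps covers this kind of change: all three concern what sits on the aromatic ring, and that ring now leaves altogether. What they do show is that the unsubstituted aryl of compound 1 gives a higher number than either substituted aryl, and that methyl and chloro are interchangeable at the digits shown. Among the compounds with values here, removing the aryl has no precedent here, so the direction is open; the prudent expectation is a step back toward the level of compound 1 rather than below compound 3. For compound 4 the expected step is a 3.0-fold higher number from compound 3 to compound 4 (0.48 log units; beyond the scatter), giving an estimate of 300 mg/kg with a range of 100 mg/kg to 600 mg/kg.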

Compound 4, minimum effective dose: 300 mg/kg
For compound 4 middle estimate and measured number coincide at the digits printed; the range from low to high includes it.
By their numbers in this assay, from the lowest: compounds 2 and 3 (each within the scatter of the next); then compounds 1 and 4 (each within the scatter of the next).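

In this assay, the aryl group on this amide-type nitrogen proves replaceable by an open chain, though the substituted aryls are not matched: propyl in place of 4-chlorophenyl gives a 3.0-fold higher number from compound 3 to compound 4 (0.48 log units; beyond the scatter), and propyl in place of 4-methylphenyl gives a 3.0-fold higher number from compound 2 to compound 4 (0.48 log units; beyond the scatter). Propyl in place of phenyl gives no change at the digits printed from compound 1 to compound 4 (within the scatter), so among these compounds the bare aromatic ring offers nothing over propyl, and the lower numbers appear only where the ring carries methyl or chloro. No accompanying data bear on why the steps at this position fall as they do.

From the compounds shown here alone, whether a longer chain such as hexyl, a cyclohexyl ring or a benzyl group on this nitrogen would stand with compound 2 and compound 3 or with compound 1 and compound 4 remains open. Also open, going by these compounds, are the effects of a carbonyl in place of the thiocarbonyl and of a methoxy group or a nitrile on the aryl ring, and whether any such group would give a number lower than those of compound 2 and compound 3.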